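Bromo for Fluoro on the Anilide Ring of Compound 3

The source may report more compounds than this note shows. Statements on the series, on what has been measured and on what is new or still open speak of the compounds shown alone.

Three compounds share one core and differ only in the ring on the amide-type nitrogen. In a functional assay on PC-3 cells (Homo sapiens) for inhibition, read by MTT assay, with a stated time of 72 h (on this read-out lower numbers stand for stronger inhibition and higher numbers for weaker inhibition), compound 1 `O=C(CSc1nc(Nc2ccccc2)c2ccccc2n1)Nc1cccc(F)c1` gives 15600 nM, compound 2 `O=C(CSc1nc(Nc2ccccc2)c2ccccc2n1)Nc1cccc([N+](=O)[O-])c1` gives 11800 nM, and compound 3 `O=C(CSc1nc(Nc2ccccc2)c2ccccc2n1)Nc1ccc(F)cc1` gives 9560 nM. Compound 3 has the smallest of the three numbers, yet both gaps to it lie within the scatter: a 1.6-fold lower number from compound 1 to compound 3 (0.21 log units; within the scatter) and a 1.2-fold lower number from compound 2 to compound 3 (0.09 log units; within the scatter). Compound 4 `O=C(CSc1nc(Nc2ccccc2)c2ccccc2n1)Nc1ccc(Br)cc1` carries bromo in place of fluoro on an aromatic carbon. Going by the values given here, no measured step swaps these two halogens; the closest comparison is a substituent swap at one ring position, a 1.3-fold lower number from compound 1 to compound 2 (0.12 log units; within the scatter), also within the scatter. No step beyond the scatter in this assay is therefore expected, and compound 4 is estimated at 9000 nM, ranging from 4000 nM to 20000 nM, meaning a 1.1-fold lower number from compound 3 to compound 4 (0.03 log units; within the scatter).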

Compound 4, half-maximal inhibitory concentration: 8450 nM
For compound 4 the middle estimate is 1.1-fold (0.03 log units) above the measured one; low and high end bracket the measured number.
By their numbers in this assay, from the lowest: compounds 4, 3, 2 and 1 (each within the scatter of the next).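

Bromo in place of fluoro, para to a large group, gives the first direct halogen swap at one ring position, and the number stays within the scatter (a 1.1-fold lower number from compound 3 to compound 4 (0.05 log units; within the scatter)). The wider steps also stay within it (a 1.4-fold lower number from compound 2 to compound 4 (0.15 log units; within the scatter); a 1.8-fold lower number from compound 1 to compound 4 (0.27 log units; within the scatter)), so all four rings on the amide-type nitrogen read alike in this assay. Nothing available explains this flat result. Still open, on these data alone, is whether an amine or a carboxylic acid on this ring would give a step beyond the scatter. Also open, as far as these compounds go, is whether changes to the shared core would matter more than changes to this ring.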